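A few compounds are considered here, and "the series" means these few. Any claim that something is new, unique, unknown or untested is made for them only; others in the source may bear on it.

Measured so far:
- compound 1, `Nc1cc(N)c2nc(-c3ccccc3)c(Oc3ccc(Cl)c(Cl)c3)nc2c1`: 14500 nM
- compound 2, `Nc1cc(N)c2nc(-c3ccccc3)c(NCc3ccc(Cl)c(Cl)c3)nc2c1`: 5130 nM

In a functional assay on PC-3 cells (Homo sapiens) for inhibition, read by sulforhodamine B assay, with a stated time of 48 h (a higher number here means a weaker inhibitor of growth, a lower number a stronger inhibitor of growth), compound 1 gives 14500 nM, and in this assay compound 2 gives 5130 nM. Compound 2 holds the lowest number of the two, and the gap to compound 1 lies beyond the scatter. Compound 2 carries the 3,4-dichlorobenzyl amine on the shared core; compound 1 carries the corresponding aryl ether instead.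

Compound 3, `COc1ccc(CNc2nc3cc(N)cc(N)c3nc2-c2ccccc2)cc1`, has not yet been run in this assay. It differs from compound 2 in one place: 4-methoxyphenyl in place of 3,4-dichlorophenyl on a saturated chain carbon bound to a nitrogen on an aromatic ring. Among the compounds with values here, no step of this kind stands among the measured pair, so the size of the change cannot be read from a prior example. A modest rise in the number, roughly within or a little beyond the scatter, is expected as the step of a 1.6-fold higher number from compound 2 to compound 3 (0.19 log units; within the scatter). For compound 3 the value in this assay is estimated at 8000 nM, with a range from 2500 nM to 25000 nM.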

Compound 3, concentration for total growth inhibition: 27500 nM
Compound 3: middle estimate off by 3.4-fold (0.54 log units), on the low side; the measured number lies above the stated range.
By their numbers in this assay, from the lowest: compound 2; then compounds 1 and 3 (each within the scatter of the next).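

On the saturated chain carbon bound to a nitrogen on an aromatic ring, this assay proves sensitive to the aryl group: 4-methoxyphenyl in place of 3,4-dichlorophenyl gives a 5.4-fold higher number from compound 2 to compound 3 (0.73 log units; beyond the scatter). Compounds 1 and 2 both carry the 3,4-dichlorophenyl group, so they offered no reading of a change in this group, and this single step now shows that the higher number goes with the 4-methoxyphenyl group. No measurement in hand bears on the reason for this step.

From the compounds shown here alone, the step removes the two chlorines and adds the methoxy group at once, so the share of each in the rise remains open. An unsubstituted phenyl at the same place would separate the two contributions, while a longer chain would test whether the distance from the nitrogen matters.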